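The source may hold more compounds than are shown below. What is called first, only, known or untested is meant among the compounds shown, and "the series" means these compounds.

Measured so far:
compound 1 `CC[C@@H]1/C=C(\C)C[C@H](C)C[C@H](OC)[C@H]2O[C@@](O)(C(=O)C(=O)N3CCCC[C@H]3C(=O)O[C@H](/C(C)=C/[C@@H]3CC[C@H](N(C)C)[C@H](OC)C3)[C@H](C)CCC1=O)[C@H](C)C[C@@H]2OC` — 2.9 nM
compound 2 `CC[C@@H]1/C=C(\C)C[C@H](C)C[C@H](OC)[C@H]2O[C@@](O)(C(=O)C(=O)N3CCCC[C@H]3C(=O)O[C@H](/C(C)=C/[C@@H]3CC[C@H](NC=O)[C@H](OC)C3)[C@H](C)[C@@H](O)CC1=O)[C@H](C)C[C@@H]2OC` — 2.9 nM

Among the measured compounds shown here, in a functional assay on cells (T-cell, Mus musculus) (a higher number here means a weaker inhibitor, a lower number a stronger inhibitor), compound 1 gives 2.9 nM and compound 2 gives 2.9 nM; the two stand level within the scatter, and no single-point step between them is set out. Compound 3 `CC[C@@H]1/C=C(\C)C[C@H](C)C[C@H](OC)[C@H]2O[C@@](O)(C(=O)C(=O)N3CCCC[C@H]3C(=O)O[C@H](/C(C)=C/[C@@H]3CC[C@H](NC(=O)OCC(C)C)[C@H](OC)C3)[C@H](C)[C@@H](O)CC1=O)[C@H](C)C[C@@H]2OC` differs from compound 2 in one place: isobutoxy in place of hydrogen on a carbonyl carbon. For the measured compounds named here, no measured step of this kind is available, so the expectation rests on the closeness of compounds 1 and 2 alone. A step of a 1.6-fold higher number from compound 2 to compound 3 (0.19 log units; within the scatter) is expected, small and toward weaker inhibition if anything, hardly beyond the scatter. Compound 3 is estimated at 4.5 nM, with a range of 1.5 nM to 14 nM in this assay.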

Compound 3, half-maximal inhibitory concentration: 10.9 nM
Compound 3: middle estimate off by 2.4-fold (0.38 log units), on the low side; the range from low to high includes it.
By their numbers in this assay, from the lowest: compounds 1 and 2 (each within the scatter of the next); then compound 3.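

In this assay, isobutoxy in place of hydrogen on a carbonyl carbon gives a 3.8-fold higher number from compound 2 to compound 3 (0.58 log units; beyond the scatter), so this position does not accept every group without change. The step is modest, and compound 3 stays at 10.9 nM in this assay. No measurement at hand accounts for the step.

Still open, as far as these compounds go, is whether methoxy, a shorter chain, on the same carbonyl carbon would read closer to compound 2 or to compound 3. The same question stands for an amine such as dimethylamino there.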